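Cyclopentylamino in place of propylamino: cytotoxicity outlook

The source may report more compounds than this note shows. Statements on the series, on what has been measured and on what is new or still open speak of the compounds shown alone.

Compound 1 `CCCNc1nc(N)nc2c1ncn2/C=C1/CC1(CO)CO` carries a propylamino group on an aromatic carbon of the shared core. In an ADME assay on BCBL1 cells (Homo sapiens) for cytotoxicity, with a stated time of 7 days (on this read-out higher numbers stand for lower toxicity in this test and lower numbers for higher toxicity in this test), compound 1 gives > 20000 nM, which is a limit of the assay and not a number. Compound 2 `CCCCCCSc1nc(N)nc2c1ncn2/C=C1/CC1(CO)CO` in this assay gives > 20000 nM, again a limit. Compound 3 `Nc1nc(N2CCCC2)c2ncn(/C=C3/CC3(CO)CO)c2n1` in this assay gives > 20000 nM, also a limit. The three steps among them, a step that the two limits leave unreadable from compound 1 to compound 2, a step that the two limits leave unreadable from compound 1 to compound 3 and a step that the two limits leave unreadable from compound 2 to compound 3, are therefore unreadable in size and direction, since every value rests at the limit of > 20000 nM in this assay, at which 3 of the 3 values shown sit.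

Compound 4 `Nc1nc(NC2CCCC2)c2ncn(/C=C3/CC3(CO)CO)c2n1` differs from compound 1 by cyclopentyl in place of propyl on a nitrogen on an aromatic ring. Going by the values given here, no measured step reads a change in this assay, so none bears directly on this difference. With every neighbour of compound 1 sitting at the limit, the expectation for compound 4 is that it too shows no toxicity within the tested range, and the step that the limit leaves unreadable from compound 1 to compound 4 is estimated to lie within the scatter. Compound 4 is expected to give about 30000 nM, with a range from 10000 nM to 100000 nM, most likely reported once more as a limit.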

Compound 4, half-maximal cytotoxic concentration: 71700 nM
Beside the measured number, compound 4's estimate is 2.4-fold (0.38 log units) below it, within the range that was stated.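

The steps from compound 1, compound 2 and compound 3 to compound 4 cannot be read, because the first three values are limits and not numbers: the limit of > 20000 nM in this assay, at which 3 of the 4 values shown sit.

The compounds shown leave open the size and direction of any effect of changing the group on this aromatic carbon in this assay.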